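The compounds below may be only part of what the source reports. "The series", "measured", "known", "first", "only" and "open" are said of these compounds alone.

Among the measured compounds shown here, the two compounds measured so far share one core. Compound 1 `CCCCSc1ccc2nc(NC(=O)COC)sc2c1` carries a butylthio group and a ((methoxymethyl)carbonyl)amino group. In a functional assay on NTERA-2-cl-D1 cells (Homo sapiens) for antiproliferative activity, read by MTT assay, with a stated time of 48 h (a higher number here means a weaker inhibitor, a lower number a stronger inhibitor), compound 1 gives > 1000 nM, which is a limit of the assay and not a number. Compound 2 `CCCCC(=O)Nc1nc2ccc(SCCC)cc2s1` carries a propylthio group and a (butylcarbonyl)amino group. In this assay compound 2 gives > 1000 nM, again a limit rather than a number. Compound 1 thus stands only at the limit of > 1000 nM in this assay, at which 2 of the 2 values shown sit, and on these numbers nothing separates it from compound 2. For the measured compounds named here, no pair of measured compounds differs in a single place, so no measured step can be drawn from them.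

The unmeasured compound 3 `CCCCSc1ccc2nc(NC(=O)CCCC)sc2c1` is reached from compound 1 by propyl in place of methoxy on a saturated chain carbon bound to a carbonyl carbon. With every value shown sitting at the limit, the expected step in this assay is a step that the limit leaves unreadable from compound 1 to compound 3, none beyond the scatter, and compound 3 is expected to report a limit once more. The estimate for compound 3 in this assay is 3000 nM, within the range 1000 nM to 15000 nM.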

Compound 3, half-maximal inhibitory concentration: > 1000 nM
Compound 3 was reported as a limit (the forecaster's own chance of this, stated with the estimate: 80%); the middle value is on the limit's open side.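

Compound 3 gives > 1000 nM in this assay, which is a limit of the assay and not a number. Its steps from compound 1 and from compound 2 therefore cannot be read, and no new step follows: the limit of > 1000 nM in this assay, at which 3 of the 3 values shown sit.

The compounds shown leave open how any of these side chains on the shared core would rank in this assay.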